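Nitro in place of chloro: compound 1 to compound 3

A few compounds are considered here, and "the series" means these few. Any claim that something is new, unique, unknown or untested is made for them only; others in the source may bear on it.

In a functional assay on L1210 cells (Mus musculus) for antiproliferative activity, read by cell counting, with a stated time of 2 days (on this read-out higher numbers stand for weaker inhibition and lower numbers for stronger inhibition), compound 1 (`COc1ccc(Nc2nc(N)c(C(=O)c3ccc(Cl)cc3)s2)cc1`) reads 84 nM and holds the higher of the two numbers in hand. For the measured compounds named here, the only other measured member, compound 2 (`COc1ccc(Nc2nc(N)c(C(=O)c3ccc(OC)c(OC)c3)s2)cc1`), reads 38 nM in this assay and the gap between the two lies beyond the usual scatter, with compound 2 the stronger inhibitor. Next to be measured is compound 3 (`COc1ccc(Nc2nc(N)c(C(=O)c3ccc([N+](=O)[O-])cc3)s2)cc1`), which carries nitro in place of chloro on an aromatic carbon, para to a large group (nitro in place of chloro on an aromatic carbon). Going by the values given here, no two measured compounds differ in one place only, so the series offers no direct precedent for this exchange. With just two values in hand, the expectation in this assay is a change within the scatter, with no favoured direction, and the range is kept wide. The expected step is a 1.1-fold higher number from compound 1 to compound 3 (0.03 log units; within the scatter) on this reasoning. Compound 3 is estimated at 90 nM with an expected range from 30 nM to 300 nM on the same read-out.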

Compound 3, half-maximal inhibitory concentration: 280 nM
The estimate for compound 3 lay 3.1-fold (0.49 log units) below the measured number, within the range that was stated.
By their numbers in this assay, from the lowest: compound 2; then compound 1; then compound 3.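

In this assay, for the compounds shown here, the exchange of chloro for nitro on an aromatic carbon para to a large group gives a 3.3-fold higher number from compound 1 to compound 3 (0.52 log units; beyond the scatter) and is the first one-place step. Compared with the two unrelated earlier values, it shows directly that this position does not tolerate every group alike, and that nitro here gives weaker inhibition than chloro. The exchange also changes several counted features at once, from 1 heavy atom to 3 and from 0 hydrogen-bond acceptors to 2, and no measurement at hand bears on why the number rises, so the step stays an observation on this single pair.

On these data alone, whether the step belongs to nitro alone or marks a wider trend at this position remains open, and an amine, a carboxylic acid or a longer chain such as butyl on the same aromatic carbon would begin to test that. Also open, as far as these compounds go, is whether the same exchange would give a similar step on another member of the series, since one pair in one cell assay cannot show how far it carries.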